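Swapping One Aryl Group for Another on a Shared Core

The source may hold more compounds than are shown below. What is called first, only, known or untested is meant among the compounds shown, and "the series" means these compounds.

Measured so far in a functional assay on HeLa cells (Homo sapiens) for inhibition, read by sulforhodamine B assay; on this read-out lower numbers stand for stronger inhibition and higher numbers for weaker inhibition:
Compound 1 `CCOc1ccccc1NC1=CC(=O)c2c(nc3n2[C@H]2OC[C@@H](O)[C@H]2OC3)C1=O` gives 8300 nM.
Compound 2 `O=C1C=C(NC2CCCC2)C(=O)c2c1nc1n2[C@H]2OC[C@@H](O)[C@H]2OC1` gives only a limit, > 16000 nM.
Compound 3 `CCCc1ccc(NC2=CC(=O)c3nc4n(c3C2=O)[C@H]2OC[C@@H](O)[C@H]2OC4)cc1` gives 4990 nM.

Compound 1 holds the higher of the two plain numbers, and compound 3 sits close to it, within the scatter. Compound 2 reaches only a limit, (the limit of > 16000 nM in this assay, at which 1 of the 3 values shown sits). Going by the values given here, the single measured step, an at least 3.2-fold lower number from compound 2 to compound 3 (0.50 log units; beyond the scatter), concerns a different kind of exchange and does not speak to swapping one aryl group for another. Compound 4 `O=C1C(Nc2ccc(I)cc2)=CC(=O)c2c1nc1n2[C@H]2OC[C@@H](O)[C@H]2OC1` carries 4-iodophenyl in place of 2-ethoxyphenyl on an amine nitrogen. Among the compounds with values here, with no measured step bearing on this change, no shift beyond the scatter is expected in this assay. Compound 4 is therefore expected to give 6500 nM, between 2500 nM and 16000 nM, an expected step of a 1.3-fold lower number from compound 1 to compound 4 (0.11 log units; within the scatter).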

Compound 4, half-maximal inhibitory concentration: 4010 nM
Compound 4: middle estimate off by 1.6-fold (0.21 log units), on the high side, within the range that was stated.
By their numbers in this assay, from the lowest: compounds 4, 3 and 1 (each within the scatter of the next, the first and the last beyond it). At a limit, above all of these: compound 2.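

Going by these compounds alone, exchanging one aryl group for another on this amine nitrogen can shift the number beyond the scatter: 4-iodophenyl in place of 2-ethoxyphenyl gives a 2.1-fold lower number from compound 1 to compound 4 (0.32 log units; beyond the scatter) in this assay while the earlier compounds held no step between two aryl groups. The step is modest, and both the substituent and its place on the ring change in it. Nothing shown accounts for this step.

Still open, on these data alone, is whether 2-iodophenyl or 4-ethoxyphenyl would separate the effect of the substituent from that of its place on the ring. As far as these compounds go, how a 4-aminophenyl or 4-carboxyphenyl group would read here also remains open.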